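The source may hold more compounds than are shown below. What is called first, only, known or untested is meant among the compounds shown, and "the series" means these compounds.

Compound 1 `c1cc(-c2nccs2)c2c(c1)C(c1ncc[nH]1)CC2` is the starting point. In a functional assay on CHO cells for agonist activity at Alpha-1B adrenergic receptor (Homo sapiens), read by FLIPR and calcium flux (a higher number here means that more compound is needed for the effect, a lower number that less compound is needed), compound 1 gives > 10000 nM, which is a limit of the assay rather than a number. Among the measured compounds shown here, two of the three values measured so far sit at that same limit (the limit of > 10000 nM in this assay, at which 2 of the 3 values shown sit). Compound 2 `Cc1n[nH]cc1-c1cccc2c1CCC2c1ncc[nH]1` carries a 3-methyl-1H-pyrazol-4-yl where compound 1 has a 1,3-thiazol-2-yl, and in this assay compound 2 gives 902 nM. The step of an at least 11-fold lower number from compound 1 to compound 2 (1.04 log units; beyond the scatter) is large. Compound 3 `CNC(=O)c1cccc2c1CCC2c1ncc[nH]1` carries a methylcarbamoyl at that position. In this assay compound 3 gives > 10000 nM, again a limit. The step of an at least 11-fold higher number from compound 2 to compound 3 (1.04 log units; beyond the scatter) is large, while the step that the two limits leave unreadable from compound 1 to compound 3 cannot be read between two limits.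

Compound 4 `c1cc(-c2ccn[nH]2)c2c(c1)C(c1ncc[nH]1)CC2` has not yet been measured. It differs from compound 1 by 1H-pyrazol-5-yl in place of 1,3-thiazol-2-yl on an aromatic carbon. The measured step that bears on this change is an at least 11-fold lower number from compound 1 to compound 2 (1.04 log units; beyond the scatter), compound 2 likewise carrying a pyrazolyl in place of the 1,3-thiazol-2-yl, so a large drop in this assay is expected here as well. For compound 4 the expected step is an at least 6.6-fold lower number from compound 1 to compound 4 (0.82 log units; beyond the scatter). Compound 4 is estimated to give 1500 nM, within a range from 400 nM to 8000 nM.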

Compound 4, half-maximal effective concentration: 600 nM
Compound 4: middle estimate off by 2.5-fold (0.40 log units), on the high side; the measured number falls inside the stated range.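

Compound 4 shows that the large drop seen with compound 2 is not tied to that one pyrazolyl group: in this assay the 1H-pyrazol-5-yl gives an at least 16-fold lower number from compound 1 to compound 4 (1.22 log units; beyond the scatter), and measured against the methylcarbamoyl it gives an at least 16-fold lower number from compound 3 to compound 4 (1.22 log units; beyond the scatter). The two pyrazolyl compounds cannot be told apart, with a 1.5-fold lower number from compound 2 to compound 4 (0.18 log units; within the scatter), so neither the methyl group nor the other point of attachment on the pyrazole shows a readable effect at this position.

Going by these compounds, whether the hydrogen-bond donor that the 1H-pyrazol-5-yl has and the 1,3-thiazol-2-yl lacks matters here stays open, and a phenyl or a pyridyl at this position would bear on that question. The true size of the steps from compound 1 and from compound 3 also stays open, as each of them starts from a limit: the limit of > 10000 nM in this assay, at which 2 of the 4 values shown sit.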